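Bromo in place of fluoro: compound 4

A few compounds are considered here, and "the series" means these few. Any claim that something is new, unique, unknown or untested is made for them only; others in the source may bear on it.

Compound 1 `COc1ccc(CN(C(=O)CSc2nc3ccccc3s2)c2cc(OC)c(OC)c(OC)c2)cc1F` gives 416 nM in a functional assay on MGC-803 cells (Homo sapiens) for antiproliferative activity, read by MTT assay, with a stated time of 48 h (on this read-out higher numbers stand for weaker inhibition and lower numbers for stronger inhibition), the lowest number of the three measured; compound 2 `COc1ccc(CN(C(=O)CSc2nc3ccccc3s2)c2cc(OC)c(OC)c(OC)c2)cc1[N+](=O)[O-]` sits nearest with 682 nM and compound 3 `COc1ccc(CN(C(=O)CSc2nc3ccccc3s2)c2cc(OC)c(OC)c(OC)c2)cc1OC` furthest with 34100 nM. Compound 4 `COc1ccc(CN(C(=O)CSc2nc3ccccc3s2)c2cc(OC)c(OC)c(OC)c2)cc1Br` differs from compound 1 by bromo in place of fluoro on an aromatic carbon. The measured steps that touch this position are a 1.6-fold higher number from compound 1 to compound 2 (0.21 log units; within the scatter) and an 82-fold higher number from compound 1 to compound 3 (1.91 log units; beyond the scatter). For the measured compounds named here, no measured step exchanges one halogen for another, so there is no direct precedent; the expectation leans on compound 2 because a 1.6-fold higher number from compound 1 to compound 2 (0.21 log units; within the scatter) shows a second small group at this position leaving the number close to that of compound 1. A step within the scatter, a 1.2-fold higher number from compound 1 to compound 4 (0.08 log units; within the scatter), is therefore expected. Compound 4 is estimated at 500 nM, in the range 200 nM to 1500 nM.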

Compound 4, half-maximal inhibitory concentration: 852 nM
Beside the measured number, compound 4's estimate is 1.7-fold (0.23 log units) below it, within the range that was stated.
By their numbers in this assay, from the lowest: compounds 1, 2 and 4 (each within the scatter of the next, the first and the last beyond it); then compound 3.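

Bromo on this carbon gives a 2.0-fold higher number from compound 1 to compound 4 (0.31 log units; beyond the scatter) as a modest step, while a 1.2-fold higher number from compound 2 to compound 4 (0.10 log units; within the scatter) leaves bromo and nitro unseparated. Against methoxy there is a 40-fold lower number from compound 3 to compound 4 (1.60 log units; beyond the scatter) as a large step, so among the four groups shown on this carbon, methoxy alone sits far from the rest.

On these data alone, whether an amine or a carboxylic acid here would stay with fluoro, nitro and bromo or fall with methoxy remains open. No data at hand explain why methoxy stands apart.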